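Aryl substituent change in a cytotoxicity series

The source may hold more compounds than are shown below. What is called first, only, known or untested is meant among the compounds shown, and "the series" means these compounds.

Compounds measured so far:
compound 1 `CCN(CC)CC(Cn1cncn1)NCc1ccccc1` — > 300000 nM in an ADME assay on CHO cells (Cricetulus griseus) for cytotoxicity, read by MTT assay; on this read-out lower numbers stand for stronger inhibition and higher numbers for weaker inhibition
compound 2 `CCN(CC)CC(Cn1cncn1)NCc1ccc(Cl)cc1` — > 300000 nM
compound 3 `CCN(CC)CC(Cn1cnc2c(N)ncnc21)NCc1ccc(Cl)cc1` — "not determined" (no result reported) in this assay
compound 4 `CCN(CC)CC(Cn1cncn1)NCc1ccc(OC)cc1` — to be measured

In this assay compound 1 gives > 300000 nM, which is a limit of the assay and not a number. Compound 2 gives > 300000 nM, again a limit and not a number. The step that the two limits leave unreadable from compound 1 to compound 2 is therefore unreadable. For compound 3 the entry is "not determined" (no result reported), so no result is reported. The two values that exist both sit at the limit of > 300000 nM in this assay, at which 2 of the 3 values shown sit, so compound 2 stands at the limit with nothing measured above or below it in the series.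

The change to compound 4 is methoxy in place of chloro on an aromatic carbon. Among the compounds with values here, the only step between measured compounds, a step that the two limits leave unreadable from compound 1 to compound 2, bears on this change but has no readable size, so no direction can be taken from it. With both reference values at the limit, the step of a number no higher from compound 2 to compound 4 (the limit leaves the size open) is expected to be none beyond the scatter, and a limit rather than a number is the likely report. Compound 4 is expected at 300000 nM, in the range 100000 nM to 1000000 nM.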

Compound 4, half-maximal inhibitory concentration: 159000 nM
Compound 4: the middle estimate sits 1.9-fold (0.28 log units) above what was measured, within the range that was stated.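

In this assay, within the data shown here, compound 4 gives 159000 nM, the only value shown that is a number and not a limit. At this position, para to a large group, the change from chloro to methoxy gives an at least 1.8-fold lower number from compound 2 to compound 4 (0.27 log units; that floor lies within the scatter), and the change from hydrogen to methoxy gives an at least 1.8-fold lower number from compound 1 to compound 4 (0.27 log units; that floor lies within the scatter). The other two readings remain limits and not numbers: the limit of > 300000 nM in this assay, at which 2 of the 4 values shown sit.

From the compounds shown here alone, the full size of both steps stays open, and the step from hydrogen to chloro cannot be read. Also open, going by these compounds, is whether an amine, a carboxylic acid or a longer chain in place of methoxy at this position would give a number in this assay, and on which side of compound 4 it would fall.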